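This account rests on a few compounds, and the source may have more. Where it says the series, first, only, none or still open, it means among the compounds named here.

Measured so far in a functional assay on A-375 cells (Homo sapiens) for antiproliferative activity, read by CCK-8 assay, with a stated time of 72 h, tested at 8 uM; a lower number here means a weaker effect, a higher number a stronger effect of the compound at the concentration tested:

- compound 1 `Nc1ccccc1NC(=O)c1ccc(CSC(=S)N2CCN(C(c3ccccc3)c3ccccc3)CC2)cc1`: 8.4%
- compound 2 `Nc1ccccc1NC(=O)c1ccc(CSC(=S)N2CCN(c3cccnc3)CC2)cc1`: 88.8%
- compound 3 `CN(C(=S)SCc1ccc(C(=O)Nc2ccccc2N)cc1)c1cccnc1`: 87.7%

Compound 3 stands second highest of the three numbers. Its nearest neighbour is compound 2, whose value lies slightly higher but within the usual scatter, so no order between compound 2 and compound 3 is claimed. Its furthest neighbour is compound 1, whose value lies far lower, well beyond the scatter. In this assay compound 1 gives 8.4%, compound 2 gives 88.8% and compound 3 gives 87.7%.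

Compound 4 `CC1CCN(C(=S)SCc2ccc(C(=O)Nc3ccccc3N)cc2)CC1` has not yet been measured in this assay. It differs from compound 3 in one place: 4-methylpiperidin-1-yl in place of methyl(pyridin-3-yl)amino on a thiocarbonyl carbon. Among the compounds with values here, no step between two measured compounds isolates this particular change, so the expectation rests on the spread of the three values alone: the two compounds with an aromatic six-membered ring on the thiocarbonyl carbon sit high, the single compound without one sits low.

For compound 4 the step of a number 32.7 percentage points lower from compound 3 to compound 4 (beyond the scatter) is expected to be downward and beyond the scatter, though with wide uncertainty. The estimate for compound 4 is 55%, within a range of 20% to 88%.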

Compound 4, a percentage reported as inhibition, at one concentration (the size of the read-out at that concentration, not a potency): 87.4%
The estimate for compound 4 lay 32.4 percentage points below the measured number; low and high end bracket the measured number.
By their numbers in this assay, from the lowest: compound 1; then compounds 4, 3 and 2 (each within the scatter of the next).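

In this assay, 4-methylpiperidin-1-yl in place of methyl(pyridin-3-yl)amino on a thiocarbonyl carbon gives a number 0.3 percentage points lower from compound 3 to compound 4 (within the scatter), so this exchange leaves the read-out unchanged within the scatter. The six-membered aromatic ring with its hetero atom is therefore not needed here for a high read-out at the tested concentration, as compound 4 carries a six-membered non-aromatic ring, and the earlier picture of high values tied to an aromatic ring at this place no longer holds. The data give no measured property that would account for this equivalence, and the single-concentration read-out does not show whether compound 3 and compound 4 are equal in potency.

What separates these high values from compound 1, at 8.4%, remains open, since the group on the thiocarbonyl carbon of compound 1 is the only one shown with a low value. As far as these compounds go, it is also open whether a morpholin-4-yl ring, a dimethylamino group or a piperidine carrying a carboxylic acid in place of the methyl would hold the read-out on this thiocarbonyl carbon.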